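Aryl swap on the core: cytotoxicity outlook for compound 3

The source may report more compounds than this note shows. Statements on the series, on what has been measured and on what is new or still open speak of the compounds shown alone.

Compound 1 `Cc1ccc(-c2ccc3[nH]c(=O)nc(-c4ccccc4)c3c2)cn1` sits at a limit in an ADME assay on L6 cells (Rattus norvegicus) for cytotoxicity, read by fluorescence and resazurin assay, with a stated time of 72 h; a higher number here means that more compound is needed for the effect, a lower number that less compound is needed: compound 1 gives > 50000 nM, a limit and not a number, as shown by the limit of > 50000 nM in this assay, at which 1 of the 2 values shown sits. Going by the values given here, compound 2 `O=c1nc(-c2ccccc2)c2cc(-c3cccc(F)c3)ccc2[nH]1` gives 23000 nM in this assay, and the step of an at least 2.1-fold lower number from compound 1 to compound 2 (0.33 log units; beyond the scatter) is the only measured change at this place. Compound 3 `N#Cc1ccc(-c2ccc3[nH]c(=O)nc(-c4ccccc4)c3c2)cc1` carries 4-cyanophenyl in place of 6-methylpyridin-3-yl on an aromatic carbon. Because an at least 2.1-fold lower number from compound 1 to compound 2 (0.33 log units; beyond the scatter) moved from a six-membered aromatic ring with one hetero atom to a carbon-only ring and lowered the number, a step of similar size in the same direction is expected here, an at least 1.6-fold lower number from compound 1 to compound 3 (0.22 log units; that floor lies within the scatter). Compound 3 is therefore estimated at 30000 nM, between 12000 nM and 50000 nM.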

Compound 3, half-maximal effective concentration: > 50000 nM
Compound 3 gave a limit, no number; the forecaster's own chance of this, stated with the estimate: 40%; at least 1.6-fold (0.22 log units) between middle value and limit.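

In this assay a carbon-only ring at this position does not by itself lower the number: 3-fluorophenyl and 4-cyanophenyl both carry one, yet the swap between them gives an at least 2.1-fold higher number from compound 2 to compound 3 (0.33 log units; beyond the scatter). The substituent on that ring therefore matters, at least for this pair. Compound 1 and compound 3 both stand at a limit, so the step between them cannot be read: the limit of > 50000 nM in this assay, at which 2 of the 3 values shown sit.

Going by these compounds, how far either compound lies past that limit remains open. Also open, on these data alone, is how an amine or a carboxylic acid would read in place of the nitrile.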